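Hydroxy to (4-methoxybenzyl)sulfanyl on the shared core

This account rests on a few compounds, and the source may have more. Where it says the series, first, only, none or still open, it means among the compounds named here.

For the measured compounds named here, only two numbers are available so far in a functional assay on RAW264.7 cells (Mus musculus) for inhibition, with stated times of 2 h and 24 h (a lower number here means a stronger inhibitor, a higher number a weaker inhibitor), for this series. Compound 1 (`COc1ccc(/C=C2/c3cc(OC)cc(OC)c3[C@@H](c3ccc(OC)cc3)[C@@H]2c2cc(OC)cc(OC)c2)cc1`) gives 6260 nM and compound 2 (`COc1cc(OC)cc([C@@H]2C(O)c3cc(OC)cc(OC)c3[C@H]2c2ccccc2)c1`) gives 3380 nM in that read-out, so the two stand level within the scatter of repeated measurements. Compound 3 (`COc1cc(OC)cc([C@@H]2C(O)c3cc(OC)cc(OC)c3[C@H]2c2ccc(F)cc2)c1`) is reported as "not active" (no number reported) with no number given. Compound 2 therefore has one numerical neighbour and one entry that cannot be placed on the scale.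

The next step leads from compound 2 to compound 4 (`COc1ccc(CSC2c3cc(OC)cc(OC)c3[C@@H](c3ccccc3)[C@@H]2c2cc(OC)cc(OC)c2)cc1`). The change is (4-methoxybenzyl)sulfanyl in place of hydroxy on a saturated ring carbon and amounts to (4-methoxybenzyl)sulfanyl in place of hydroxy on a saturated ring carbon.

Going by the values given here, no two measured compounds differ in one place only, so the size of this step cannot be read from the series. Compound 1 has no hydroxy group and still gives 6260 nM in this assay as a measurable number, which argues against a large expected change. Compound 3 at "not active" (no number reported) keeps an outcome without a number open. The expected step of a 1.2-fold higher number from compound 2 to compound 4 (0.07 log units; within the scatter) stays within the scatter, with no firm direction. For compound 4 the estimated value is 4000 nM with an expected range from 1000 nM to 16000 nM around it.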

Compound 4, half-maximal inhibitory concentration: > 200000 nM
Compound 4 gave a limit, no number (the forecaster's own chance of this, stated with the estimate: 30%); at least 50-fold (1.69 log units) between middle value and limit.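

Within this assay, exchanging hydroxy for (4-methoxybenzyl)sulfanyl on this saturated ring carbon gives an at least 59-fold higher number from compound 2 to compound 4 (1.77 log units; beyond the scatter), the first step in the series that can be read for a change in one place. For the compounds shown here, it shows that the position does not accept this replacement without a large loss of inhibition, which the earlier compounds could not show, as no two of them differ in one place only. As far as these compounds go, the reading for compound 4 is a limit of the assay and not a number, so the true size of the step stays unknown and only its lower bound is printed: the limit of > 200000 nM in this assay, at which 1 of the 4 values shown sits.

The change removes the hydroxy group, with its hydrogen-bond donor, and adds a sulfur link, a benzyl ring and a methoxy group all at once, so the compounds shown cannot assign the step to the loss of hydroxy or to any single part of the entering group. A small group on the same carbon, such as an amine or a methylsulfanyl group, would separate these two readings.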